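This account rests on a few compounds, and the source may have more. Where it says the series, first, only, none or still open, it means among the compounds named here.

Compound 1 `Nc1ncnc2c1c(-c1cc(C3CC3)on1)nn2C1CCCCC1`: 2000 nM
Compound 2 `CC(C)n1nc(/C=N/OCc2ccccc2)c2c(N)ncnc21`: > 10000 nM

In an assay on BaF3 cells for inhibition of proto-oncogene tyrosine-protein kinase receptor Ret variant V804M (Homo sapiens), read by MTT assay, with a stated time of 48 h (on this read-out higher numbers stand for weaker inhibition of growth and lower numbers for stronger inhibition of growth), compound 1 gives 2000 nM, the only number shown. Compound 2 stops at a limit of the assay, > 10000 nM, so it gives no number (the limit of > 10000 nM in this assay, at which 1 of the 2 values shown sits). Compound 3 `Cn1nc(-c2cc(C3CC3)on2)c2c(N)ncnc21` is not yet measured; it differs from compound 1 by methyl in place of cyclohexyl on an aromatic nitrogen. Going by the values given here, no measured pair shows this change, so its size is open. A weakening beyond the scatter is expected, a step of a 3.0-fold higher number from compound 1 to compound 3 (0.48 log units; beyond the scatter). Compound 3 is therefore expected at 6000 nM, within 1500 nM to 20000 nM.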

Compound 3, concentration for 50% growth inhibition: 5560 nM
Estimate against measurement, compound 3: 1.1-fold (0.03 log units) above; low and high end bracket the measured number.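

Replacing cyclohexyl with methyl on the aromatic nitrogen gives a 2.8-fold higher number from compound 1 to compound 3 (0.44 log units; beyond the scatter) in this assay, so the group at this position does affect growth inhibition. The step is modest, and compound 3 still gives a measured number, so the cyclohexyl ring is not needed for that. Nothing measured here shows why the number changes.

This single pair cannot show how the number follows the group between these two extremes. As far as these compounds go, a longer carbon chain, or a chain ending in an amine, on this nitrogen remains open.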